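The source may hold more compounds than are shown below. What is called first, only, known or untested is meant among the compounds shown, and "the series" means these compounds.

Working notes on the series. Compound 1 `CC(=O)N1c2ccccc2CCC1C(=O)Nc1cc(C(F)(F)F)cc(C(F)(F)F)c1` carries an acetyl on the carbonyl carbon whose other neighbour is the amide-type nitrogen in a ring. In a functional assay on PC-3 cells (Homo sapiens) for cytotoxicity, read by sulforhodamine B assay, with a stated time of 72 h (on this read-out lower numbers stand for stronger inhibition of growth and higher numbers for weaker inhibition of growth), compound 1 gives only a limit, > 70000 nM, which is the limit (the limit of > 70000 nM in this assay, at which 1 of the 3 values shown sits). Compound 2 `CCC(=O)N1c2ccccc2CCC1C(=O)Nc1ccccc1C(F)(F)F` likewise gives only a limit in this assay, > 80000 nM, the limit (the limit of > 80000 nM in this assay, at which 1 of the 3 values shown sits). Compound 3 `O=C(Nc1ccccc1C(F)(F)F)C1CCc2ccccc2N1C(=O)c1ccccc1` gives 5560 nM in this assay. Going by the values given here, the single measured step, an at least 14-fold lower number from compound 2 to compound 3 (1.15 log units; beyond the scatter), shows that an aryl on that carbonyl carbon in place of a short alkyl moves the read-out well beyond the scatter. Compound 4 `O=C(Nc1cc(C(F)(F)F)cc(C(F)(F)F)c1)C1CCc2ccccc2N1C(=O)c1ccc(Cl)cc1` is the counterpart of compound 1 after (4-chlorophenyl in place of methyl on a carbonyl carbon). The change is of the same kind as the measured step: an aryl enters on the carbonyl carbon where an alkyl stood. The expected step in this assay is therefore large and downward, an at least 14-fold lower number from compound 1 to compound 4 (1.14 log units; beyond the scatter). Compound 1 stands at a limit, and the expected size of the step is accordingly bounded on one side only. Compound 4 is estimated at 5000 nM, expected to fall between 1000 nM and 30000 nM.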

Compound 4, concentration for 50% growth inhibition: 4230 nM
The estimate for compound 4 lay 1.2-fold (0.07 log units) above the measured number; low and high end bracket the measured number.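

In this assay the series now shows an at least 16-fold lower number from compound 1 to compound 4 (1.21 log units; beyond the scatter), so the large drop seen with phenyl in place of ethyl also appears with 4-chlorophenyl in place of methyl, on a different aryl amide part. The carbonyl carbon whose other neighbour is the amide-type nitrogen in a ring therefore responds to an aryl in both measured pairs, and the response does not hang on one aryl amide part alone. Compound 1 remains a limit and not a number, so this step is bounded on one side only: the limit of > 70000 nM in this assay, at which 1 of the 4 values shown sits.

No pair shown differs in the chlorine alone, so what it adds to the phenyl ring stays unknown. Also open, as far as these compounds go, is how a longer chain such as hexyl, a saturated ring such as cyclohexyl, or an aminophenyl would read at this carbonyl carbon.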